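This account rests on a few compounds, and the source may have more. Where it says the series, first, only, none or still open, it means among the compounds named here.

Two compounds of this series have been run in a functional assay on Ramos cells (Homo sapiens) for inhibition, read by MTT assay, with a stated time of 48 h; on this read-out higher numbers stand for weaker inhibition and lower numbers for stronger inhibition. Compound 1 `C=CC(=O)Nc1cccc(Oc2ncnc3ccc(-c4ccc(F)nc4)cc23)c1` gives 11000 nM in this assay. Compound 2 `C=CC(=O)Nc1cccc(Oc2ncnc3ccc(-c4cnc5ccccc5c4)cc23)c1` gives 10600 nM in this assay. For the measured compounds named here, the single measured step, a 1.0-fold lower number from compound 1 to compound 2 (0.02 log units; within the scatter), exchanges one aryl group for another on an aromatic carbon of the shared core and stays within the scatter. On the two numbers shown, compound 2 holds the lower one, but its gap to compound 1 is within the scatter, so the two cannot be placed in order.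

Compound 3 `C=CC(=O)Nc1cccc(Oc2ncnc3ccc(-c4cccnc4)cc23)c1` remains to be measured. It differs from compound 2 in one place: pyridin-3-yl in place of quinolin-3-yl on an aromatic carbon. Going by the values given here, the only measured step that bears on this position is a 1.0-fold lower number from compound 1 to compound 2 (0.02 log units; within the scatter); it, too, swapped one aryl group for another at the same aromatic carbon and produced no change beyond the scatter. On that basis the expected step in this assay is a 1.1-fold lower number from compound 2 to compound 3 (0.03 log units; within the scatter), that is, none beyond the scatter. Compound 3 is therefore estimated at 10000 nM, with a range from 4000 nM to 25000 nM.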

Compound 3, half-maximal inhibitory concentration: 9400 nM
Beside the measured number, compound 3's estimate is 1.1-fold (0.03 log units) above it; measured number inside the range.
By their numbers in this assay, from the lowest: compounds 3, 2 and 1 (each within the scatter of the next).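

In this assay the aromatic carbon of the shared core now tolerates a larger structural change than the earlier aryl swap: going from quinolin-3-yl to pyridin-3-yl, from 10 heavy atoms to 6 and without the six-membered aromatic ring of carbon only, gives a 1.1-fold lower number from compound 2 to compound 3 (0.05 log units; within the scatter) and stays within the scatter. The fluoro group on the pyridine ring is likewise dispensable for the read-out, since hydrogen in its place gives a 1.2-fold lower number from compound 1 to compound 3 (0.07 log units; within the scatter) and also stays within the scatter. The three compounds therefore cannot be placed in order, and neither the second fused ring nor the fluoro group separates them in this assay. No evidence at hand accounts for this flat response.

The compounds shown contain only neutral aromatic groups at this carbon and so leave open whether an aminomethyl group or a carboxylic acid on the pyridin-3-yl ring, or a saturated amine such as morpholine in place of that ring, would shift the number beyond the scatter. They also leave open whether any change at this carbon can bring the number well under the level shared by all three compounds.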